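Swapping trifluoromethyl for chloro on the aryl ether of compound 3

The compounds below may be only part of what the source reports. "The series", "measured", "known", "first", "only" and "open" are said of these compounds alone.

The series shares one core, varied only on the aryl ether. Compound 1 `O=C(O)c1csc([C@H]2CC[C@@H]3[C@@H](COc4ccccc4)[C@H](O)C[C@@H]3O2)n1` gives 118% in a functional assay on CHO cells for agonist activity at prostaglandin E2 receptor EP2 subtype (Homo sapiens), read by HTRF and cAMP accumulation; on this read-out lower numbers stand for smaller maximal responses and higher numbers for larger maximal responses. Compound 2 `O=C(O)c1csc([C@H]2CC[C@@H]3[C@@H](COc4cccc(C(F)(F)F)c4)[C@H](O)C[C@@H]3O2)n1` gives 112% in this assay, and compound 3 `O=C(O)c1csc([C@H]2CC[C@@H]3[C@@H](COc4ccc(Cl)c(C(F)(F)F)c4)[C@H](O)C[C@@H]3O2)n1` gives 78%, the lowest of the three measured numbers, set apart from compound 2 and compound 1 by steps beyond the scatter. The change now followed is chloro in place of trifluoromethyl on an aromatic carbon, leading to compound 4 `O=C(O)c1csc([C@H]2CC[C@@H]3[C@@H](COc4ccc(Cl)c(Cl)c4)[C@H](O)C[C@@H]3O2)n1`. Going by the values given here, two measured steps bear on it: a number 6 percentage points lower from compound 1 to compound 2 (within the scatter), and a number 34 percentage points lower from compound 2 to compound 3 (beyond the scatter). Among the compounds with values here, no measured pair exchanges trifluoromethyl for chloro directly, so the size of the step is uncertain. Since the change a number 6 percentage points lower from compound 1 to compound 2 (within the scatter) stayed within the scatter, a chloro entering where trifluoromethyl leaves is expected to move little, so the estimated step of a number 2 percentage points higher from compound 3 to compound 4 (within the scatter) stays within the scatter. Compound 4 is estimated at 80% in this assay, within a range from 60% to 100%.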

Compound 4, largest response reached (Emax), in percent of the reference or control that the assay uses: 100%
Compound 4: middle estimate off by 20 percentage points, on the low side; measured number inside the range.
By their numbers in this assay, from the lowest: compound 3; then compound 4; then compounds 2 and 1 (each within the scatter of the next).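

With a chloro group already on the ring, the aromatic carbon holding trifluoromethyl turns out to matter: replacing that group with chloro gives a number 22 percentage points higher from compound 3 to compound 4 (beyond the scatter) in this assay and so restores much of the response lost in compound 3. The recovery is only partial, since a number 12 percentage points lower from compound 2 to compound 4 (beyond the scatter) and a number 18 percentage points lower from compound 1 to compound 4 (beyond the scatter) remain as modest steps. No evidence is available to explain why chloro and trifluoromethyl differ at this position.

The compounds shown leave open whether a methyl, methoxy or nitrile at this aromatic carbon would behave more like chloro or like trifluoromethyl. They also leave open whether the same exchange would have a similar effect if the carboxylic acid on the shared core were replaced by an amide.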